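Swapping Fluoro for Chloro in Compound 2

The source may report more compounds than this note shows. Statements on the series, on what has been measured and on what is new or still open speak of the compounds shown alone.

For the measured compounds named here, compound 2 `O=C(NCc1cn(Cc2ccc(F)cc2)nn1)c1cn(-c2ccccc2)nc1-c1ccc(F)cc1` is one of only two compounds measured in a functional assay on HeLa cells (Homo sapiens) for antiproliferative activity, read by sulforhodamine B assay, with a stated time of 48 h (a higher number here means a weaker inhibitor of growth, a lower number a stronger inhibitor of growth), where compound 2 gives 1200 nM. Its sole comparator, compound 1 `O=C(NCc1cn(Cc2ccc(F)cc2)nn1)c1cn(-c2ccccc2)nc1-c1ccccc1`, gives 1600 nM in this assay. The two numbers sit close together, as a 1.3-fold lower number from compound 1 to compound 2 (0.12 log units; within the scatter) shows, so neither compound can be ranked ahead of the other. Compound 3 `O=C(NCc1cn(Cc2ccc(F)cc2)nn1)c1cn(-c2ccccc2)nc1-c1ccc(Cl)cc1` has not yet been measured. It differs from compound 2 in a single substituent: chloro in place of fluoro on an aromatic carbon. Going by the values given here, no measured step exchanges one halogen for another; the only step in hand, that from compound 1 to compound 2, introduced fluoro where hydrogen had been and stayed within the scatter. On that basis the exchange is expected to move this assay little, if at all, with a 1.2-fold lower number from compound 2 to compound 3 (0.08 log units; within the scatter) as the estimated step. Compound 3 is therefore estimated at 1000 nM, within a range from 400 nM to 2500 nM.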

Compound 3, concentration for 50% growth inhibition: 2800 nM
Compound 3: the middle estimate sits 2.8-fold (0.45 log units) below what was measured, and the stated range ends below it.
By their numbers in this assay, from the lowest: compounds 2, 1 and 3 (each within the scatter of the next, the first and the last beyond it).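

At this position, para to a large group, the choice of halogen made a readable difference in this assay: the exchange of fluoro for chloro gave a 2.3-fold higher number from compound 2 to compound 3 (0.37 log units; beyond the scatter), the first step among these compounds to pass beyond the scatter. Chloro in place of hydrogen gave a 1.8-fold higher number from compound 1 to compound 3 (0.24 log units; within the scatter), so compound 1 cannot be separated from either halogen compound, and only compound 2 and compound 3 stand apart from each other. Nothing available bears on what lies behind this step.

From the compounds shown here alone, whether a bromo or a methoxy group at the same place would fall nearer to compound 2 or to compound 3 remains open. A single exchange also cannot show whether fluoro and chloro would separate in the same way on another core.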